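Isopropyl in Place of Isobutyl on an Aryl Ether

This account rests on a few compounds, and the source may have more. Where it says the series, first, only, none or still open, it means among the compounds named here.

Compound 1 `Oc1cc(-c2ccccc2)nc2c(O)cccc12` is measured in a functional assay on P388 cells (Mus musculus) for cytotoxicity; a lower number here means that less compound is needed, a higher number that more compound is needed for the effect; the result for compound 1 is the limit > 10 ug/mL.
Compound 2 `CC(C)COc1cc(-c2ccccc2)nc2ccccc12` also reaches only the limit, with compound 2 giving > 10 ug/mL.
Compound 3 `Oc1cc(-c2ccccc2)nc2cc(F)ccc12` gives a number, with compound 3 at 0.29 ug/mL.

Compound 2 therefore stands at the limit of this assay, not at a number, and it shares this position with compound 1, as described by the limit of > 10 ug/mL in this assay, at which 2 of the 3 values shown sit. Only compound 3, which carries a free hydroxyl and a fluorine instead of an ether, gives a measured concentration.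

Compound 4 `CC(C)Oc1cc(-c2ccccc2)nc2ccccc12` differs from compound 2 in one place: isopropyl in place of isobutyl on an oxygen on an aromatic ring. For the measured compounds named here, no measured pair shows what such a change does here, so the expectation rests on compound 2 alone. Because compound 2 sits at > 10 ug/mL, the step that the limit leaves unreadable from compound 2 to compound 4 is expected to be none beyond the scatter, with compound 4 most likely again reported only as a limit. Compound 4 is estimated at 15 ug/mL, within a range from 5 ug/mL to 50 ug/mL.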

Compound 4, half-maximal effective concentration: > 10 ug/mL
Compound 4: a limit, no number; the forecaster's own chance of this, stated with the estimate: 75%; the middle value does not contradict the limit.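

For the compounds shown here, compound 2 and compound 4 each stop at a limit of the assay rather than a number, so no step between them can be read: the limit of > 10 ug/mL in this assay, at which 3 of the 4 values shown sit. The compounds shown leave open whether isopropyl and isobutyl on this oxygen differ at all in this assay.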